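This account rests on a few compounds, and the source may have more. Where it says the series, first, only, none or still open, it means among the compounds named here.

Working notes on the pyridopyrimidinone-free description of the series: four compounds, one assay.

Compound 1 `O=C(Nc1ccc(Oc2ccnc3[nH]ccc23)c(F)c1)c1cc2cccnc2n(-c2ccc(F)cc2)c1=O` is the reference. In a functional assay on A549 cells (Homo sapiens) for antiproliferative activity, read by MTT assay, with a stated time of 72 h (a higher number here means a weaker inhibitor, a lower number a stronger inhibitor), compound 1 gives 62 nM. Compound 2 `O=C(Nc1ccc(Oc2ccnc3[nH]ccc23)c(F)c1)c1cc2cccnc2n(-c2ccc(Cl)cc2)c1=O` differs from it in one place, (chloro in place of fluoro on an aromatic carbon), and in this assay compound 2 gives 110 nM; the step is a 1.8-fold higher number from compound 1 to compound 2 (0.25 log units; within the scatter). Compound 3 `Cn1ccc2c(Oc3ccc(NC(=O)c4cc5cccnc5n(-c5ccc(F)cc5)c4=O)cc3)ccnc21` carries a different core; the difference between the core of compound 1 and the core of compound 3 is not broken down here. In this assay, among the compounds with values here, compound 3 gives 210 nM, the highest of the three numbers so far, with its gap to compound 2 within the scatter and its gap to compound 1 beyond it.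

Compound 4 `Cn1ccc2c(Oc3ccc(NC(=O)c4cc5cccnc5n(-c5ccc(Cl)cc5)c4=O)cc3)ccnc21` has not been measured in this assay. It stands to compound 3 as compound 2 stands to compound 1: the change is chloro in place of fluoro on an aromatic carbon, the same change as in the measured pair, at a place described in the same words, so that the change occurs in two pairs among the compounds shown. Within the data shown here, the only measured instance of it is a 1.8-fold higher number from compound 1 to compound 2 (0.25 log units; within the scatter), which is within the scatter.

Among the measured compounds shown here, the step from compound 3 to compound 4 in this assay is therefore expected to be about the same size, a 1.8-fold higher number from compound 3 to compound 4 (0.25 log units; within the scatter), because a 1.8-fold higher number from compound 1 to compound 2 (0.25 log units; within the scatter) is the one measured instance of this change and nothing in the data suggests it should read differently on the core of compound 3. On that basis compound 4 is estimated at 370 nM in this assay, with an expected range from 170 nM to 800 nM.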

Compound 4, half-maximal inhibitory concentration: 630 nM
Compound 4: the middle estimate sits 1.7-fold (0.23 log units) below what was measured; the measured number falls inside the stated range.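

In this assay, chloro in place of fluoro on the core of compound 3 gives a 3.0-fold higher number from compound 3 to compound 4 (0.48 log units; beyond the scatter), a step beyond the scatter, whereas the same change on the core of compound 1 stayed within it. Set side by side, the two steps cannot be told apart, so the 4-fluorophenyl to 4-chlorophenyl change carries from one core to the other as far as these two pairs can show: the same change on two cores in this assay, a 1.8-fold higher number (0.25 log units; within the scatter) from compound 1 to compound 2 and a 3.0-fold higher number (0.48 log units; beyond the scatter) from compound 3 to compound 4, 1.7-fold (0.23 log units) apart, within the scatter of two such steps. Within the data shown here, this does not show that the step has one fixed size on every core of the series: there are only two pairs, and the data neither establish nor exclude a real dependence of the step on the core, and they give no reason for the size of either step.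

The compounds shown leave open how other groups at this same place on the aromatic ring, such as an amine or a methoxy group, would read against fluoro and chloro on either core. They also leave open which part of the difference between the core of compound 1 and the core of compound 3 accounts for the gap between those two compounds, as no compound separates the parts of that difference.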